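The compounds below may be only part of what the source reports. "The series", "measured", "known", "first", "only" and "open" are said of these compounds alone.

In a functional assay on HCT-116 cells (Homo sapiens) for inhibition, read by colorimetric assay, with a stated time of 3 days (on this read-out lower numbers stand for stronger inhibition and higher numbers for weaker inhibition), compound 1 `O=C(CCCCCCNC(=O)C(O)(O)C(F)(F)F)Nc1ccccc1Br` gives 14500 nM, compound 2 `O=C(CCCCCCNC(=O)C(O)(O)C(F)(F)F)Nc1ccccc1` gives 9140 nM, and compound 3 `O=C(CCCCCCNC(=O)C(O)(O)C(F)(F)F)Nc1ccc(Cl)cc1` gives 4230 nM. Compound 3 therefore has the lowest number of the three, and its gap to each of the others lies beyond the scatter. The next compound, compound 4 `O=C(CCCCCCNC(=O)C(O)(O)C(F)(F)F)Nc1cccc(Br)c1`, has 3-bromophenyl in place of 4-chlorophenyl on an amide-type nitrogen.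

Among the measured compounds shown here, no measured compound carries the 3-bromophenyl group, so the available steps guide the expectation only indirectly. Hydrogen in place of bromo gave a 1.6-fold lower number from compound 1 to compound 2 (0.20 log units; within the scatter), which stays within the scatter. Chloro in place of hydrogen gave a 2.2-fold lower number from compound 2 to compound 3 (0.33 log units; beyond the scatter), a modest change. The swap of one halogen-bearing ring for another, 4-chlorophenyl in place of 2-bromophenyl, gave a 3.4-fold lower number from compound 1 to compound 3 (0.54 log units; beyond the scatter), also modest.

Neither bromo comparison shows a gain, and compound 3 holds its lead over compound 2 by only the modest 2.2-fold lower number from compound 2 to compound 3 (0.33 log units; beyond the scatter). Losing the 4-chlorophenyl group is thus expected to move the number a small way upward in this assay, towards the other two compounds. The estimated step is a 1.7-fold higher number from compound 3 to compound 4 (0.22 log units; within the scatter). Compound 4 is expected at about 7000 nM, with an estimated range of 3000 nM to 16000 nM.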

Compound 4, half-maximal inhibitory concentration: 3060 nM
The estimate for compound 4 lay 2.3-fold (0.36 log units) above the measured number, within the range that was stated.
By their numbers in this assay, from the lowest: compounds 4 and 3 (each within the scatter of the next); then compounds 2 and 1 (each within the scatter of the next).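

In this assay, among the compounds shown here, the 3-bromophenyl group is the first bromo-bearing ring here to separate from the plain phenyl ring (a 3.0-fold lower number from compound 2 to compound 4 (0.48 log units; beyond the scatter)), whereas the 2-bromophenyl group did not (a 1.6-fold lower number from compound 1 to compound 2 (0.20 log units; within the scatter)). The two bromo compounds also differ clearly from each other (a 4.7-fold lower number from compound 1 to compound 4 (0.68 log units; beyond the scatter)), so with the same halogen on the same kind of ring, the position shown in the group's name makes a modest difference to the number. Exchanging 4-chlorophenyl for 3-bromophenyl, which changes both the halogen and its position, gives a difference that cannot be told from repeat-measurement noise (a 1.4-fold lower number from compound 3 to compound 4 (0.14 log units; within the scatter)), so these two rings perform alike in this cell test.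

No evidence here explains why the bromo rings differ. The compounds shown leave open whether the halogen itself or its position drives these numbers, and how a fluoro group, a methoxy group, an amine or a carboxylic acid on the ring would compare, or a longer chain in place of the shared one.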